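Swapping phenoxy for methylsulfonyl on a cytotoxicity screen

A few compounds are considered here, and "the series" means these few. Any claim that something is new, unique, unknown or untested is made for them only; others in the source may bear on it.

Measured compounds so far:
Compound 1 `CC(C)N(Cc1cccc(OCCCCCC(=O)O)c1)C(=O)c1ccc(-c2cccc3ccccc23)cc1` is one of three compounds in an ADME assay on HEK293 cells (Homo sapiens) for cytotoxicity, read by CellTiter-Glo and resazurin assay, with a stated time of 72 h; a higher number here means that more compound is needed for the effect, a lower number that less compound is needed. In this assay compound 1 gives only a limit, > 26000 nM.
Compound 2 `CC(C)N(Cc1cccc(OCCCCCC(=O)O)c1)C(=O)c1ccc(-c2cccc(Oc3ccccc3)c2)cc1` is the second. In this assay compound 2 also gives only a limit, > 18700 nM.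
Compound 3 `COc1ccc(F)c(-c2ccc(C(=O)N(Cc3cccc(OCCCCCC(=O)O)c3)C(C)C)cc2)c1` is the third. In this assay compound 3 again gives only a limit, > 26000 nM.

All three share the same core, differing only in the group on the outer aromatic ring. Among the compounds with values here, compound 2 stands at a limit rather than a number, and the two other values shown are limits as well, so no compound can be ranked against another here.

Compound 4 `CC(C)N(Cc1cccc(OCCCCCC(=O)O)c1)C(=O)c1ccc(-c2cccc(S(C)(=O)=O)c2)cc1` is not yet measured. It differs from compound 2 by methylsulfonyl in place of phenoxy on an aromatic carbon. The change sits on an aromatic carbon of a six-membered aromatic ring of carbon only, meta to a large group.

Within the data shown here, only one measured step is available, a step that the two limits leave unreadable from compound 1 to compound 3, and its size cannot be read from the two limits. What the data do show is the limit of > 18700 nM in this assay, at which 1 of the 3 values shown sits, and (the limit of > 26000 nM in this assay, at which 2 of the 3 values shown sit), so every change tried so far on this ring has left the compound without a measurable effect.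

Compound 4 is therefore expected to follow the same pattern, with an estimated 30000 nM (range 10000 nM to 100000 nM), and the step that the limit leaves unreadable from compound 2 to compound 4 is expected to be no more than the scatter.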

Compound 4, half-maximal effective concentration: > 26000 nM
Compound 4 ended at the assay's limit; the forecaster's own chance of this, stated with the estimate: 85%; the middle value is on the limit's open side.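

In this assay compound 4 gives > 26000 nM, which is a limit of the assay. Within the data shown here, compound 1, compound 2 and compound 3 also stand at limits, so no step from any of them to compound 4 can be read. The compounds shown leave open at what concentration any of them would show an effect, and whether changing this group would alter it.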